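The source may hold more compounds than are shown below. What is called first, only, known or untested is meant among the compounds shown, and "the series" means these compounds.

For the measured compounds named here, in an ADME assay on BaF3 cells (Mus musculus) for cytotoxicity (on this read-out higher numbers stand for an effect only at larger amounts of compound and lower numbers for an effect already at smaller amounts), the three measured members all sit at the same limit. Compound 1 `Nc1cccc(-c2cc(Nc3ccc(OC(F)(F)F)cc3)ncn2)c1` returns only a limit, > 10000 nM. Compound 3 `FC(F)(F)c1ccc(Nc2cc(-c3ccncc3)ncn2)cc1` likewise returns a limit, > 10000 nM. Compound 2 `FC(F)(F)Oc1ccc(Nc2ncnc3nn(C4CCCCC4)cc23)cc1` stands with them, giving a limit of > 10000 nM; this is the limit of > 10000 nM in this assay, at which 3 of the 3 values shown sit, so no ordering among the three can be drawn. Compound 4 `CCn1cc2c(Nc3ccc(OC(F)(F)F)cc3)ncnc2n1` is not yet measured. It differs from compound 2 by ethyl in place of cyclohexyl on an aromatic nitrogen. Going by the values given here, with no measured step to lean on, no shift beyond the scatter is expected in this assay; the estimated step from compound 2 to compound 4 is a step that the limit leaves unreadable from compound 2 to compound 4. Compound 4 is expected to give about 15000 nM, in a range from 6000 nM to 40000 nM, most likely reported once more as a limit.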

Compound 4, half-maximal effective concentration: > 10000 nM
Compound 4: a limit, no number; the forecaster's own chance of this, stated with the estimate: 85%; the middle value is on the limit's open side.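

Compound 2 and compound 4 both return only limits, so no step can be read between them: the limit of > 10000 nM in this assay, at which 4 of the 4 values shown sit. The compounds shown leave open whether ethyl in place of cyclohexyl on an aromatic nitrogen shifts anything in this assay and at what concentration any of them would give a number.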